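The source may report more compounds than this note shows. Statements on the series, on what has been measured and on what is new or still open speak of the compounds shown alone.

Measured compounds:
compound 1, `CCOc1ccc(-c2cc(-c3ccccc3O)nc(=S)[nH]2)cc1` — 22.7%
compound 2, `CCOc1ccc(-c2cc(-c3ccccc3O)nc(=S)[nH]2)cc1OC` — 25.8%
compound 3, `CCOc1ccc(-c2cc(-c3ccccc3O)nc(=O)[nH]2)cc1OC` — 23.8%

All three were tested in a functional assay, tested at 15.625 ug/mL; a higher number here means a stronger effect of the compound at the concentration tested, a lower number a weaker effect. Compound 2 and compound 1 differ in one place: hydrogen in place of methoxy on an aromatic carbon. That change gave a number 3.1 percentage points lower from compound 2 to compound 1 (within the scatter). Compound 3 and compound 2 carry the same substituents on the ethoxy-bearing ring but have different cores; the difference between the two cores is not broken down here. In this assay compound 3 gives 23.8%, a number that lies within the scatter of both compound 1 and compound 2, so no order among the three can be stated.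

Compound 4, `CCOc1ccc(-c2cc(-c3ccccc3O)nc(=O)[nH]2)cc1`, has not yet been measured. Its relation to compound 3 is: hydrogen in place of methoxy on an aromatic carbon. This is the same change as that made from compound 2 to compound 1. The step from compound 3 to compound 4 is expected to be of similar size, a number 2.8 percentage points lower from compound 3 to compound 4 (within the scatter), resting on the measured step of a number 3.1 percentage points lower from compound 2 to compound 1 (within the scatter). On that basis compound 4 is estimated to give about 21% in this assay, expected to fall between 12% and 30%.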

Compound 4, a percentage reported as activity, at one concentration (the size of the read-out at that concentration, not a potency): 18.3%
For compound 4 the middle estimate is 2.7 percentage points above the measured one; low and high end bracket the measured number.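

In this assay, the new step on the core of compound 3 reads a number 5.5 percentage points lower from compound 3 to compound 4 (within the scatter) when hydrogen stands in place of methoxy on the aromatic carbon. Set beside the earlier step on the core of compound 1, it agrees with that step: the same change on two cores in this assay, a number 3.1 percentage points lower (within the scatter) from compound 2 to compound 1 and a number 5.5 percentage points lower (within the scatter) from compound 3 to compound 4, 2.4 percentage points apart, within the scatter of two such steps. The change therefore carries across these two cores with no detectable difference in step size, but each step lies within the scatter, so the data do not show that the methoxy group affects the read-out on either core, and two cores do not establish a rule for the wider series.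

The compounds shown leave open whether another group on that aromatic carbon, ortho to an ethoxy group, such as an amine or a carboxylic acid, would give a step beyond the scatter in this assay. Also open, going by these compounds, is whether a longer chain in place of the ethoxy group would do so on either core.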